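Adding two chlorines to the phenyl of compound 3

The source may report more compounds than this note shows. Statements on the series, on what has been measured and on what is new or still open speak of the compounds shown alone.

In a functional assay on FM3A cells (Mus musculus) for antiproliferative activity (a lower number here means a stronger inhibitor, a higher number a weaker inhibitor), compound 3 `COc1cc(C(=O)c2sc(-c3ccccc3)cc2N)cc(OC)c1OC` gives 13 nM. Compound 2 `COc1cc(C(=O)c2sc(-c3cccc([N+](=O)[O-])c3)cc2N)cc(OC)c1OC`, at 17 nM, cannot be told apart from it, since a 1.3-fold lower number from compound 2 to compound 3 (0.12 log units; within the scatter). Compound 1 `COc1cc(C(=O)c2sc(-c3ccc([N+](=O)[O-])cc3)cc2N)cc(OC)c1OC` gives 64 nM and stands clearly apart from both. Here a 4.9-fold lower number from compound 1 to compound 3 (0.69 log units; beyond the scatter), and a 3.8-fold lower number from compound 1 to compound 2 (0.58 log units; beyond the scatter).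

The next step leads to compound 4 `COc1cc(C(=O)c2sc(-c3ccc(Cl)c(Cl)c3)cc2N)cc(OC)c1OC`, with 3,4-dichlorophenyl in place of phenyl on an aromatic carbon. Among the measured compounds shown here, no chlorine-bearing compound has been measured, so the only guide is what nitro does on the same ring. Compound 4 carries substituents at both of the ring places that nitro occupies singly in compound 1 and compound 2. One of those placements cost activity, as a 4.9-fold lower number from compound 1 to compound 3 (0.69 log units; beyond the scatter) shows, while the other cost nothing beyond the scatter, as a 1.3-fold lower number from compound 2 to compound 3 (0.12 log units; within the scatter) shows. A modest rise in the number is therefore more likely than none, though the evidence is thin and a result level with compound 3 would not surprise. The expected change is a 2.7-fold higher number from compound 3 to compound 4 (0.43 log units; beyond the scatter). For compound 4 the estimated value is 35 nM, with an expected range of 10 nM to 120 nM.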

Compound 4, half-maximal inhibitory concentration: 400 nM
Estimate against measurement, compound 4: 11-fold (1.06 log units) below; the whole stated range lies below it.
By their numbers in this assay, from the lowest: compounds 3 and 2 (each within the scatter of the next); then compound 1; then compound 4.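

In this assay, the 3,4-dichlorophenyl group at this place, next to the ring sulfur, proves far more costly than the opening nitro compounds suggested (a 31-fold higher number from compound 3 to compound 4 (1.49 log units; beyond the scatter)). The loss is also large against the compound carrying 3-nitrophenyl (a 24-fold higher number from compound 2 to compound 4 (1.37 log units; beyond the scatter)) and still clear against the one carrying 4-nitrophenyl (a 6.3-fold higher number from compound 1 to compound 4 (0.80 log units; beyond the scatter)), which had been the weakest of the first three and is now surpassed in loss by compound 4, the weakest of the four. So this position does not merely separate one nitrophenyl from the other: a substituted phenyl here can lose much more activity than either nitrophenyl did, and nothing shown explains why this group costs so much.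

The compounds shown leave open whether one chlorine on the phenyl would already bring this loss or whether it takes both chlorines together. They also leave open how a phenyl bearing a methyl group, an amine or a carboxylic acid would fare at this same place on the shared core.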